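This account rests on a few compounds, and the source may have more. Where it says the series, first, only, none or still open, it means among the compounds named here.

Measured compounds in an assay on isolated protein for agonist activity at Free fatty acid receptor 1 (Homo sapiens); a higher number here means that more compound is needed for the effect, a lower number that less compound is needed:
Compound 1 `CC#CC(CC(=O)O)c1ccc(OCc2ccc3nc(-c4ccccc4C)cn3c2)cc1` gives 389 nM.
Compound 2 `CC#CC(CC(=O)O)c1ccc(OCc2ccn3cc(-c4ccc(C(C)C)cc4)nc3c2)cc1` gives 615 nM.

For the measured compounds named here, compound 2 carries the higher of the two numbers, but its only neighbour, compound 1, lies at a gap within the usual scatter, so the two cannot be placed in any order. Going by the values given here, no pair of measured compounds that differ in a single place is available, so there is no measured step to lean on. Compound 3 `CC#CC(CC(=O)O)c1ccc(OCc2ccn3cc(-c4ccccc4F)nc3c2)cc1` has not yet been measured in this assay. It differs from compound 2 in one place: 2-fluorophenyl in place of 4-isopropylphenyl on an aromatic carbon. Both the group that leaves and the group that enters are a single six-membered aromatic ring of carbon only, without hydrogen-bond donors or acceptors and without net charge, on the same aromatic carbon of the shared core. A change of this kind, on what is known here, gives no reason to expect a step beyond the scatter. The expected step of a 1.4-fold lower number from compound 2 to compound 3 (0.14 log units; within the scatter) is therefore small, leaning if anything toward a lower number. Compound 3 is estimated at 450 nM, within a range from 150 nM to 1400 nM.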

Compound 3, half-maximal effective concentration: 705 nM
For compound 3 the middle estimate is 1.6-fold (0.19 log units) below the measured one; the range from low to high includes it.
By their numbers in this assay, from the lowest: compounds 1, 2 and 3 (each within the scatter of the next).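

In this assay, for the compounds shown here, putting 2-fluorophenyl in place of 4-isopropylphenyl on an aromatic carbon of the five-membered ring gives a 1.1-fold higher number from compound 2 to compound 3 (0.06 log units; within the scatter), the first step here between compounds that differ in only one place. This step lies within the scatter, so these two compounds cannot be told apart, even though the two groups differ in their substituent and in where it sits on the six-membered ring. For this pair, then, the change leaves the read-out without a visible shift, and nothing measured here shows why the two compounds read alike.

Both groups are single six-membered aromatic rings of carbon only, so this one step says nothing about how a different kind of group at the same place, such as an amine, a pyridine ring or a short alkyl chain, would read. Going by these compounds, it also remains open how a plain phenyl ring would compare, and that compound would be needed to show what the isopropyl group and the fluorine each contribute on their own.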